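Swapping a pyridinyl for a chlorophenyl on the ring nitrogen

The compounds below may be only part of what the source reports. "The series", "measured", "known", "first", "only" and "open" are said of these compounds alone.

Three compounds sharing one core have been run in a functional assay on CHO cells with adenosine receptor A1 (Homo sapiens) as the target, read by cAMP accumulation and immunoassay, with a stated time of 6 min, tested at 0.1 uM; a higher number here means a weaker effect of the compound at the concentration tested, a lower number a stronger effect. Compound 1 `Nc1scc(CN2CCN(c3ccncc3)CC2)c1C(=O)c1ccc(Cl)cc1` gives 1.4%, the highest of the three numbers. Compound 2 `Nc1scc(CN2CCN(c3ccc(C(F)(F)F)cc3)CC2)c1C(=O)c1cccc(C(F)(F)F)c1` gives -11%, and compound 3 `Nc1scc(CN2CCN(c3cccc(F)c3)CC2)c1C(=O)c1cccc(C(F)(F)F)c1` gives -12%; both numbers stand beyond the scatter below compound 1. Among the compounds with values here, the only single-point change among them, a number 1 percentage points lower from compound 2 to compound 3 (within the scatter), shows that trading one aryl group for another on the amine nitrogen in the ring left the read-out unchanged.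

The new compound 4 `Nc1scc(CN2CCN(c3cccc(Cl)c3)CC2)c1C(=O)c1ccc(Cl)cc1` differs from compound 1 as follows: 3-chlorophenyl in place of pyridin-4-yl on an amine nitrogen in a ring. This is again a trade of the group on the amine nitrogen in a six-membered non-aromatic ring with 2 nitrogen, the same place altered from compound 2 to compound 3. That one step was flat, so a large move is not expected here. Compound 2 and compound 3, which carry carbon-only rings at that position, do sit lower than compound 1, but they differ from it elsewhere too, so that gap cannot be credited to the ring nitrogen alone.

On balance the expected step is a number 5.4 percentage points lower from compound 1 to compound 4 (within the scatter), a small move that may fall within the scatter. Compound 4 is estimated at -4%, with a range from -17% to 9%.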

Compound 4, a percentage reported as activity, at one concentration (the size of the read-out at that concentration, not a potency): -20%
For compound 4 the middle estimate is 16 percentage points above the measured one, outside the stated range (below it).
By their numbers in this assay, from the lowest: compounds 4, 3 and 2 (each within the scatter of the next); then compound 1.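

Within the data shown here, this step gives the first clean reading at this position. Among these compounds, with the rest of compound 1 kept, 3-chlorophenyl in place of pyridin-4-yl on an amine nitrogen in a ring gives a number 21.4 percentage points lower from compound 1 to compound 4 (beyond the scatter) in this assay, whereas the only earlier step at this position, a number 1 percentage points lower from compound 2 to compound 3 (within the scatter), was flat. The group on this nitrogen can therefore move the read-out, at least when the starting group is pyridin-4-yl, and the change involves two things at once: the ring nitrogen leaves and a chlorine enters. No measurement at hand says why the read-out moves.

An unsubstituted phenyl group on the same nitrogen would help separate the part of the step that goes with losing the ring nitrogen from the part that goes with gaining the chlorine. The compounds shown also leave open how a non-aromatic group there, such as cyclohexyl or a simple methyl, would compare, and each read-out here is the size of the effect at one concentration, so none of them gives a potency.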